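A few compounds are considered here, and "the series" means these few. Any claim that something is new, unique, unknown or untested is made for them only; others in the source may bear on it.

Compound 1 `CNC(=O)c1cccc2nc(-c3c[nH]c4c(F)c(F)c(F)cc34)ccc12` is the longest-lived of the three compounds measured in an ADME assay on microsomes from liver (Homo sapiens) for metabolic stability, using NADPH, with a stated time of 40 min, tested at 2 uM; on this read-out higher numbers stand for a longer-lived compound and lower numbers for a shorter-lived compound: compound 1 gives 1.17 h. Compound 2 `Clc1cccc2c(-c3ccc4ccccc4n3)c[nH]c12` gives 0.283 h, and compound 3 `Fc1cc(Cl)c2[nH]cc(-c3ccc4ccccc4n3)c2c1` gives 0.383 h; both fall beyond the scatter below compound 1, with compound 3 standing nearest and compound 2 furthest.

Compound 4 `Fc1cc2c(-c3ccc4ccccc4n3)c[nH]c2c(F)c1F` has not yet been measured. It differs from compound 1 in one place: hydrogen in place of methylcarbamoyl on an aromatic carbon. For the measured compounds named here, no measured pair shows exactly this change. Going by the values given here, the only step that is available, a 1.4-fold higher number from compound 2 to compound 3 (0.13 log units; within the scatter), concerns a different change on the other ring system and is within the scatter, so it says little about what removing the methylcarbamoyl will do. What the data do show is that the two measured compounds that lack a methylcarbamoyl, compound 2 and compound 3, both sit well below compound 1, while the ring that carries the fluorines in compound 4 is shared with compound 1.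

On that basis the expectation is a shorter half-life for compound 4, a step of about a 2.6-fold lower number from compound 1 to compound 4 (0.41 log units; beyond the scatter), beyond the scatter. Compound 4 is therefore estimated at 0.45 h, with a range from 0.2 h to 1 h.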

Compound 4, half-life: 0.25 h
The estimate for compound 4 lay 1.8-fold (0.26 log units) above the measured number, and the stated range covers the measured number.
By their numbers in this assay, from the lowest: compounds 4, 2 and 3 (each within the scatter of the next); then compound 1.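

Putting hydrogen in place of the methylcarbamoyl on this aromatic carbon gives a 4.7-fold lower number from compound 1 to compound 4 (0.67 log units; beyond the scatter) in this assay and is a step beyond the scatter, so this one position clearly matters for the half-life. The earlier compounds shown here could only hint at this, as none of the measured pairs isolated the change, whereas compound 1 and compound 4 differ in this place alone and keep the same three fluorines on the shared core. Those fluorines therefore do not by themselves keep the half-life at the level of compound 1, although nothing measured here explains why the half-life falls when the methylcarbamoyl leaves.

The compounds shown compare only methylcarbamoyl and hydrogen at this position, so it remains open whether a nitrile, a carboxylic acid or an amide with a longer chain would keep the half-life of compound 1 or lose it. Going by these compounds, it is also open whether adding a methylcarbamoyl at the same place would lengthen the half-life by a similar amount on a core carrying chlorine, such as that of compound 3.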